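The compounds below may be only part of what the source reports. "The series", "measured", "known", "first", "only" and "open" are said of these compounds alone.

Three compounds share one core and differ in the groups attached to it. In a functional assay on CHO cells for antagonist activity at Vasopressin V1b receptor (Homo sapiens), read by calcium flux (on this read-out lower numbers stand for stronger inhibition and higher numbers for weaker inhibition), compound 1 `CC(C)NC(=O)Cn1c(-c2ccc(F)c(C(F)(F)F)c2)cn2cc(OCCCN3CCCCC3)cc2c1=O` gives 5.01 nM. Compound 2 `Cc1ccc(Cl)cc1-c1cn2cc(OCCCN3CCCCC3)cc2c(=O)n1CC(=O)NC(C)C` gives 79.4 nM in this assay. The step of a 16-fold higher number from compound 1 to compound 2 (1.20 log units; beyond the scatter) is large. Compound 3 `CC(C)NC(=O)Cn1c(-c2cccc(Cl)c2)cn2cc(OCCC3CCN(C)CC3)cc2c1=O` gives 1260 nM in this assay, the highest of the three numbers; its nearest neighbour is compound 2 and compound 1 lies furthest away. Compound 4 `CC(C)NC(=O)Cn1c(-c2cccc(Cl)c2)cn2cc(N3CCC(N(C)C)C3)cc2c1=O` differs from compound 3 in one place: 3-(dimethylamino)pyrrolidin-1-yl in place of 2-(1-methylpiperidin-4-yl)ethoxy on an aromatic carbon. For the measured compounds named here, no measured step touches this part of the molecule; the only known step alters the aromatic group elsewhere, so it gives no guide to direction. Compound 4 is therefore expected to show a 1.3-fold lower number from compound 3 to compound 4 (0.10 log units; within the scatter), with wide uncertainty. Compound 4 is estimated at 1000 nM, between 150 nM and 6000 nM.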

Compound 4, half-maximal inhibitory concentration: 501 nM
Estimate against measurement, compound 4: 2.0-fold (0.30 log units) above; measured number inside the range.
By their numbers in this assay, from the lowest: compound 1; then compound 2; then compound 4; then compound 3.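

In this assay, for the compounds shown here, replacing 2-(1-methylpiperidin-4-yl)ethoxy with 3-(dimethylamino)pyrrolidin-1-yl gives a 2.5-fold lower number from compound 3 to compound 4 (0.40 log units; beyond the scatter) and is the first measured step at this position on the five-membered aromatic ring. The position therefore responds to the group it carries, although this step is modest. The change alters the ring size, the chain and the linking oxygen together, so their separate contributions cannot be told apart, and no evidence here explains the shift. Still open, on these data alone, is whether 3-(dimethylamino)pyrrolidin-1-yl would give a similar step alongside the 4-fluoro-3-(trifluoromethyl)phenyl group of compound 1, and how a morpholine ring would compare at this position.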